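Three limits in one assay and a phenol to come

The source may report more compounds than this note shows. Statements on the series, on what has been measured and on what is new or still open speak of the compounds shown alone.

Measured compounds:
- compound 1 `COc1ccc(C(=O)/C=C/c2ccc(N(c3ccccc3)c3ccccc3)cc2)c2c1C=CC(C)(C)O2`: > 10000 nM
- compound 2 `COc1ccc(C(=O)/C=C/c2ccc(C(F)(F)F)cc2)c2c1C=CC(C)(C)O2`: > 10000 nM
- compound 3 `COc1ccc(C(=O)/C=C/c2cccc3ccccc23)c2c1C=CC(C)(C)O2`: > 10000 nM

Every number above in a functional assay on SK-OV-3 cells (Homo sapiens) for antiproliferative activity, read by MTT assay, with a stated time of 24 h (a higher number here means a weaker inhibitor, a lower number a stronger inhibitor), is a limit of the assay and not a measured value. Compound 2 gives > 10000 nM in this assay, which is only a limit. The same holds for compound 1 and compound 3, each sitting at the limit as well, so the three measured compounds cannot be ordered against one another; all that is known is the limit of > 10000 nM in this assay, at which 3 of the 3 values shown sit.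

The unmeasured compound 4 `COc1ccc(C(=O)/C=C/c2ccc(O)cc2)c2c1C=CC(C)(C)O2` differs from compound 2 by hydroxy in place of trifluoromethyl on an aromatic carbon. Within the data shown here, no step between measured compounds exists, since every value is a limit, so nothing measured tells how this exchange should move the readout in this assay. The three measured analogues differ from one another in the same region of the structure and none of them reached a number, which gives no ground to expect compound 4 to behave otherwise.

The expectation for compound 4 in this assay is therefore 15000 nM, within a range from 3000 nM to 60000 nM, and the expected step from compound 2 to compound 4 is a step that the limit leaves unreadable from compound 2 to compound 4, which is no change beyond the scatter; most likely the assay again reports a limit rather than a number.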

Compound 4, half-maximal inhibitory concentration: > 10000 nM
Compound 4: a limit, no number; the forecaster's own chance of this, stated with the estimate: 70%; the middle value does not contradict the limit.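

In this assay compound 4 gives > 10000 nM, which is a limit and not a number. Compound 2 and compound 4 therefore give no readable step for hydroxy in place of trifluoromethyl: the limit of > 10000 nM in this assay, at which 4 of the 4 values shown sit.

The compounds shown leave open what size of effect, if any, any of these changes has in this assay.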